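Working notes: from compound 2 to compound 4

The compounds below may be only part of what the source reports. "The series", "measured", "known", "first", "only" and "open" are said of these compounds alone.

Measured so far in an assay on HeLa cells with Bile acid receptor (Homo sapiens) as the target, read by a luciferase reporter, with a stated time of 24 h; on this read-out lower numbers stand for an effect already at smaller amounts and higher numbers for an effect only at larger amounts of compound:
- compound 1, `CC(C)(C)c1ccc(C(=O)NCc2ccc(N)cc2Cl)cc1`, gives 46 nM
- compound 2, `CSc1ccc(CNC(=O)c2ccc(C(C)(C)C)cc2)cc1`, gives 100 nM
- compound 3, `CC(C)(C)c1ccc(C(=O)NCc2cccc(C(=O)O)c2)cc1`, gives 1700 nM

Three compounds share the same amide-linked core and differ only in the substituted benzylic ring. On the numbers shown, compound 2 has the second highest value of the three. Its nearest neighbour is compound 1, whose lower number lies beyond the usual scatter; the furthest is compound 3, whose much higher number is also well beyond the scatter. Compound 2 therefore sits between the two, closer to compound 1.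

The next compound, compound 4, `CC(C)Oc1ccc(CNC(=O)c2ccc(C(C)(C)C)cc2)cc1`, differs from compound 2 in one place: isopropoxy in place of methylsulfanyl on an aromatic carbon. Both the leaving and the entering group are uncharged and carry a single hydrogen-bond acceptor; the entering group is larger by two carbon atoms and sits at the same place on the ring. Within the data shown here, no measured pair in this set isolates such a change, so nothing here shows how the read-out responds to it. Among the measured compounds shown here, with no comparable step to draw on, the expected step is a 1.2-fold higher number from compound 2 to compound 4 (0.08 log units; within the scatter), none beyond the scatter. Compound 4 is thus estimated at about 120 nM in this assay, with a range from 40 nM to 400 nM.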

Compound 4, half-maximal effective concentration: 170 nM
Compound 4: middle estimate off by 1.4-fold (0.15 log units), on the low side; low and high end bracket the measured number.
By their numbers in this assay, from the lowest: compound 1; then compounds 2 and 4 (each within the scatter of the next); then compound 3.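

In this assay, among these compounds, a 1.7-fold higher number from compound 2 to compound 4 (0.23 log units; within the scatter) comes from isopropoxy in place of methylsulfanyl on an aromatic carbon para to a large group, the first step that differs in one place. At this position, the read-out does not separate the two groups, even though the entering group has more heavy atoms and oxygen replaces sulfur; both carry no hydrogen-bond donors, one hydrogen-bond acceptor and no net charge. No measurement bears on why compound 2 and compound 4 lie within the scatter of each other.

The compounds shown leave open whether the added carbons and the exchange of sulfur for oxygen each matter on their own, since this single pair changes both at once and a methoxy group at the same place would be needed to pull them apart. They also leave open how the read-out responds at this position to a longer chain such as butoxy or to a hydroxyl group, and whether the tolerance seen here extends beyond these two groups.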